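The source may hold more compounds than are shown below. What is called first, only, known or untested is meant among the compounds shown, and "the series" means these compounds.

Compound 2 `Cc1nc(C)c(-c2nn(-c3ccc(F)cc3)cc2C2CC(c3cc(Cl)ccc3O)=NN2)s1` stands only at a limit, not a number: in an ADME assay on HeLa cells (Homo sapiens) for inhibition, read by MTT assay (a lower number here means a stronger inhibitor of growth, a higher number a weaker inhibitor of growth), compound 2 gives > 250 ug/mL. Compound 1 `Cc1nc(C)c(-c2nn(-c3ccc(F)cc3)cc2/C=C/C(=O)c2cc(Cl)cc(Cl)c2O)s1` is likewise reported only as a limit, > 250 ug/mL in this assay, so that (the limit of > 250 ug/mL in this assay, at which 2 of the 2 values shown sit). Compound 3 `Cc1nc(C)c(-c2nn(-c3ccc(F)cc3)cc2C2CC(c3cc(Cl)c(C)cc3O)=NN2)s1` awaits measurement. It differs from compound 2 by methyl in place of hydrogen on an aromatic carbon. Going by the values given here, with both known values resting at the limit, no step in this assay can be sized from the data, and none beyond the scatter is expected. The estimated step is a step that the limit leaves unreadable from compound 2 to compound 3. Compound 3 is expected at 300 ug/mL, within 120 ug/mL to 800 ug/mL, most probably again a limit.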

Compound 3, concentration for 50% growth inhibition: > 250 ug/mL
Compound 3: only a limit was reported (the forecaster's own chance of this, stated with the estimate: 80%); the middle value is on the limit's open side.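

No step can be read from compound 2 to compound 3, as both values are limits: the limit of > 250 ug/mL in this assay, at which 3 of the 3 values shown sit.
The compounds shown leave open how strongly any of them inhibits growth, and whether methyl in place of hydrogen on an aromatic carbon alters it.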